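A few compounds are considered here, and "the series" means these few. Any claim that something is new, unique, unknown or untested is made for them only; others in the source may bear on it.

In a functional assay on MCF7 cells (Homo sapiens) for antiproliferative activity, read by MTT assay, with a stated time of 48 h (on this read-out lower numbers stand for stronger inhibition and higher numbers for weaker inhibition), compound 2 (`Cc1ccc(/C=C/C(=O)Nc2nnc(-c3ccc(C)cc3)s2)cc1`) gives 0.61 ug/mL and its two measured neighbours, compound 1 (`Cc1ccc(-c2nnc(NC(=O)/C=C/c3ccc(C(F)(F)F)cc3)s2)cc1`) with 1.1 ug/mL and compound 3 (`Cc1ccc(/C=C/C(=O)Nc2nnc(-c3ccccc3)s2)cc1`) with 1.23 ug/mL in the same read-out, both lie within the scatter of it. The change to compound 4 (`Cc1ccc(-c2nnc(NC(=O)/C=C/c3ccccc3)s2)cc1`) is hydrogen in place of methyl on an aromatic carbon. Among the measured compounds shown here, two measured steps bear on it. The same exchange on the other aromatic ring gives a 2.0-fold higher number from compound 2 to compound 3 (0.30 log units; within the scatter) and a replacement on the ring changing here gives a 1.8-fold lower number from compound 1 to compound 2 (0.26 log units; within the scatter) (both within the scatter). The expected step in this assay is a 1.6-fold higher number from compound 2 to compound 4 (0.21 log units; within the scatter) towards a higher number, and it is not expected to go beyond the scatter. For compound 4 the estimate is 1 ug/mL (expected range 0.5 ug/mL to 2.2 ug/mL).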

Compound 4, half-maximal inhibitory concentration: 1.19 ug/mL
For compound 4 the middle estimate is 1.2-fold (0.08 log units) below the measured one; the measured number falls inside the stated range.
By their numbers in this assay, from the lowest: compounds 2, 1, 4 and 3 (each within the scatter of the next).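

In this assay this position now carries methyl, trifluoromethyl and hydrogen, and the steps are a 2.0-fold higher number from compound 2 to compound 4 (0.29 log units; within the scatter) for hydrogen in place of methyl and a 1.1-fold higher number from compound 1 to compound 4 (0.03 log units; within the scatter) for hydrogen in place of trifluoromethyl. The phenyl compound therefore stands within the scatter of both substituted compounds, so the three groups at this position are not separated by this read-out. No measurement shown accounts for this result. From the compounds shown here alone, whether an amine or a carboxylic acid at this position would give a step beyond the scatter remains open.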